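Alkoxy-quinoline series: extending the ether chain toward benzyl

A few compounds are considered here, and "the series" means these few. Any claim that something is new, unique, unknown or untested is made for them only; others in the source may bear on it.

Measured so far:
compound 1 `CCCCOc1ccc2c(Cl)ccnc2c1`: 2640 nM
compound 2 `CCOc1ccc2c(Cl)ccnc2c1`: 2660 nM

In a functional assay on HepG2 cells (Homo sapiens) for cytotoxicity, read by MTT assay, with a stated time of 48 h (a lower number here means a stronger inhibitor, a higher number a weaker inhibitor), compound 1 gives 2640 nM and compound 2 gives 2660 nM. Compound 2 sits at the top of the two numbers recorded, but it is separated from compound 1 only by a 1.0-fold higher number from compound 1 to compound 2 (0.00 log units; within the scatter), so the two are indistinguishable on this evidence.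

Compound 3 `Clc1ccnc2cc(OCCCc3ccccc3)ccc12` is the next member, not yet measured in this assay. Relative to compound 2 it carries benzyl in place of hydrogen on a saturated chain carbon, two bonds along the chain from an oxygen on an aromatic ring. Within the data shown here, the single measured step that bears on this place is the one from compound 1 to compound 2, where dropping an ethyl from the same chain carbon changed nothing beyond the scatter. The benzyl entering in compound 3 is a larger group than the ethyl that left, so the step is not a strict reversal, and nothing recorded so far speaks to a ring at this place. On the evidence in hand, the expected step is small: the estimate for compound 3 corresponds to a 1.2-fold lower number from compound 2 to compound 3 (0.08 log units; within the scatter), with no clear direction beyond the scatter.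

For compound 3 the expected value in this assay is therefore 2200 nM, with a range of 800 nM to 6000 nM.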

Compound 3, half-maximal inhibitory concentration: 1780 nM
Compound 3: middle estimate off by 1.2-fold (0.09 log units), on the high side; the measured number falls inside the stated range.
By their numbers in this assay, from the lowest: compounds 3, 1 and 2 (each within the scatter of the next).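

In this assay the earlier pair covered only the removal of an ethyl at this place, whereas benzyl in place of hydrogen on a saturated chain carbon, two bonds along the chain from an oxygen on an aromatic ring, adds a six-membered aromatic ring of carbon only and gives a 1.5-fold lower number from compound 2 to compound 3 (0.17 log units; within the scatter) in this series. Read against the butyl ether, phenyl in place of methyl on a saturated chain carbon, three bonds along the chain from an oxygen on an aromatic ring, gives a 1.5-fold lower number from compound 1 to compound 3 (0.17 log units; within the scatter) and so leads to the same reading. A ring and 7 heavy atoms can therefore enter at this place with no step beyond the scatter, and the three compounds remain undistinguished in this assay; no supporting evidence accompanies this result.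

Open, going by these compounds, is whether an amine or a carboxylic acid at this place, or a longer chain carrying the phenyl ring, would give a step beyond the scatter. Also open, on these data alone, is whether a fluorine on the ring of the benzyl group would leave the number as flat as the present steps.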